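The source may hold more compounds than are shown below. What is called first, only, known or untested is meant among the compounds shown, and "the series" means these compounds.

Measured in a functional assay on HepG2 cells (Homo sapiens) for antiproliferative activity, read by MTT assay, with a stated time of 48 h; a lower number here means a stronger inhibitor of growth, a higher number a weaker inhibitor of growth:
compound 1 `COC(=O)N1N=C(c2cccc(OC)c2)CC1c1cc(OC)c(OC)c(OC)c1` gives 1870 nM
compound 2 `COC(=O)N1N=C(c2ccc(OC)cc2)CC1c1cc(OC)c(OC)c(OC)c1` gives 1710 nM
compound 3 `COc1ccc(C2=NN(C(=O)OCc3ccccc3)C(c3cc(OC)c(OC)c(OC)c3)C2)cc1` gives > 10000 nM, which is a limit and not a number

Compound 2, at 1710 nM, stands level with compound 1 within the scatter, as a 1.1-fold lower number from compound 1 to compound 2 (0.04 log units; within the scatter) shows. Only these two compounds give numbers.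

Compound 4 `COC(=O)N1N=C(c2cccc(C)c2)CC1c1cc(OC)c(OC)c(OC)c1` is the next to be read against compound 2. It carries 3-methylphenyl in place of 4-methoxyphenyl on a carbon with a double bond to nitrogen. The methoxycarbonyl group of compound 2 stays unchanged.

Two measured steps are available. The one at the same place, a 1.1-fold lower number from compound 1 to compound 2 (0.04 log units; within the scatter), only moved the methoxy group around the phenyl ring and stayed within the scatter. The larger one, an at least 5.8-fold higher number from compound 2 to compound 3 (0.76 log units; beyond the scatter), lies at the ester, a part of the molecule that compound 4 does not alter, so it bears little on this change. Going by the values given here, no measured step replaces methoxy with methyl, which leaves the expectation loose. No step beyond the scatter is expected in this assay, with a slight drift to a higher number as the only lean.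

The estimated step is a 1.3-fold higher number from compound 2 to compound 4 (0.11 log units; within the scatter).
For compound 4 the expected value is 2200 nM, with an estimated range from 800 nM to 6500 nM.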

Compound 4, concentration for 50% growth inhibition: 980 nM
Compound 4: the middle estimate sits 2.2-fold (0.35 log units) above what was measured; the measured number falls inside the stated range.
By their numbers in this assay, from the lowest: compounds 4, 2 and 1 (each within the scatter of the next). At a limit, above all of these: compound 3.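

In this assay, 3-methylphenyl in place of 4-methoxyphenyl on the carbon with a double bond to nitrogen gives a 1.7-fold lower number from compound 2 to compound 4 (0.24 log units; within the scatter), so this position takes a group with no oxygen and no hydrogen-bond acceptor and stays level with compound 2; the earlier pair only moved the methoxy group around the phenyl ring. The direct exchange of methyl for methoxy on an aromatic carbon, a 1.9-fold lower number from compound 1 to compound 4 (0.28 log units; within the scatter), reads the same way, and compound 1, compound 2 and compound 4 thus form one level across two substituents and two ring positions. No measured property among the data at hand bears on this result.

Still open is whether this tolerance extends to a very different substituent on the phenyl ring, such as an amine, a carboxylic acid or a longer alkoxy chain, none of which is covered by the three aryl groups shown. Also open, going by these compounds, is how a small change to the methoxycarbonyl group, such as an ethyl ester or an amide, would read against this level.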